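This account rests on a few compounds, and the source may have more. Where it says the series, first, only, none or still open, it means among the compounds named here.

Compound 1 `COC(=O)c1nc(C)n(-c2ccc(C(F)(F)F)cc2)n1` gives 16600 nM in a functional assay on NCI-H226 cells (Homo sapiens) for inhibition, read by MTT assay, with a stated time of 72 h; on this read-out lower numbers stand for stronger inhibition of growth and higher numbers for weaker inhibition of growth.
Compound 2 `COC(=O)c1nc(C)n(-c2ccc(Cl)cc2)n1` gives 84000 nM in this assay.
Compound 3 `COC(=O)c1nc(C)n(-c2ccc(F)cc2)n1` gives 11700 nM in this assay.

Compound 3 carries the lowest of the three numbers, but only in part with clear margin: the step of a 7.2-fold lower number from compound 2 to compound 3 (0.86 log units; beyond the scatter) lies beyond the scatter, while a 1.4-fold lower number from compound 1 to compound 3 (0.15 log units; within the scatter) lies within it, so compound 3 and compound 1 cannot be set in order. Compound 4 `CCCCc1nc(C(=O)OC)nn1-c1ccc(F)cc1` differs from compound 3 by propyl in place of hydrogen on a saturated chain carbon bound to an aromatic carbon. Within the data shown here, every measured step exchanges a group on an aromatic carbon; none of them touches this chain, so no measured step bears on the change from compound 3 to compound 4, and the expectation rests on compound 3 alone. For compound 4 the expected step is a 1.1-fold lower number from compound 3 to compound 4 (0.03 log units; within the scatter) in this assay, with a wide uncertainty. The estimate for compound 4 is 11000 nM, expected to fall between 3000 nM and 45000 nM.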

Compound 4, concentration for 50% growth inhibition: 6400 nM
Compound 4: middle estimate off by 1.7-fold (0.24 log units), on the high side, and the stated range covers the measured number.
By their numbers in this assay, from the lowest: compounds 4, 3 and 1 (each within the scatter of the next, the first and the last beyond it); then compound 2.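

This is the first change shown at the saturated chain carbon bound to an aromatic carbon. In this assay propyl in place of hydrogen, which also reads as methyl to butyl, gives a 1.8-fold lower number from compound 3 to compound 4 (0.26 log units; within the scatter). The number therefore stays within the scatter with butyl on the chain, and no measurement on hand explains this result. Still open, as far as these compounds go, is whether a longer chain or a chain ending in an amine would keep the number there. Also open, from the compounds shown here alone, is whether butyl would behave alike with chloro or trifluoromethyl on the aromatic carbon.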